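The compounds below may be only part of what the source reports. "The series", "measured", "known", "first", "only" and "open" are said of these compounds alone.

In a functional assay on M21 cells (Homo sapiens) for antiproliferative activity, read by sulforhodamine B assay, with a stated time of 48 h (on this read-out lower numbers stand for stronger inhibition and higher numbers for weaker inhibition), compound 1 (`Cc1ccc(NS(=O)(=O)c2ccc(N3CCNC3=O)cc2)cc1`) gives 260 nM and compound 2 (`Cc1ccc(NS(=O)(=O)c2ccc(N3CCNC3=O)cc2)cc1C`) gives 94 nM while compound 3 (`O=C1NCCN1c1ccc(S(=O)(=O)Nc2ccccc2)cc1`) gives 200 nM and so cannot be separated from compound 1 but stands above compound 2. Compound 4 (`O=C1NCCN1c1ccc(S(=O)(=O)Nc2ccc(F)c(F)c2)cc1`) differs from compound 3 by one change (3,4-difluorophenyl in place of phenyl on a sulfonamide nitrogen), 3,4-difluorophenyl in place of phenyl on a sulfonamide nitrogen. The closest measured change gives a 2.1-fold higher number from compound 2 to compound 3 (0.33 log units; beyond the scatter) for phenyl in place of 3,4-dimethylphenyl, whereas hydrogen in place of methyl gives only a 1.3-fold lower number from compound 1 to compound 3 (0.11 log units; within the scatter) in the same series. Read in reverse, the first of these points to a lower number for compound 4, though no fluorinated compound has been measured. The expected move in this assay is small and downward (a 1.7-fold lower number from compound 3 to compound 4 (0.22 log units; within the scatter)). Compound 4 is estimated at 120 nM (expected range 50 nM to 280 nM).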

Compound 4, half-maximal inhibitory concentration: 220 nM
The estimate for compound 4 lay 1.8-fold (0.26 log units) below the measured number; the measured number falls inside the stated range.
By their numbers in this assay, from the lowest: compound 2; then compounds 3, 4 and 1 (each within the scatter of the next).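

In this assay, 3,4-difluorophenyl on the sulfonamide nitrogen cannot be separated from phenyl (a 1.1-fold higher number from compound 3 to compound 4 (0.04 log units; within the scatter)) or from 4-methylphenyl (a 1.2-fold lower number from compound 1 to compound 4 (0.07 log units; within the scatter)), but it gives a higher number than 3,4-dimethylphenyl (a 2.3-fold higher number from compound 2 to compound 4 (0.37 log units; beyond the scatter)). Of the four groups at this position, only 3,4-dimethylphenyl now stands apart, and adding two fluorines to phenyl gives no readable change. Nothing available bears on why these groups behave this way.

Still open, on these data alone, is whether ethyl, methoxy, an amine or a carboxylic acid on this aromatic ring would match 3,4-dimethylphenyl. Also open, as far as these compounds go, is whether changes to the shared core would shift these numbers.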